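Changing the aryl on the triazole nitrogen: from chloro to dinitro

The source may report more compounds than this note shows. Statements on the series, on what has been measured and on what is new or still open speak of the compounds shown alone.

Measured so far:
- compound 1, `CCOc1ccc(-n2nncc2CN2C(=O)C3(C(C#N)=C(N)Oc4c3c3nc5ccccc5nc3c3ccccc43)c3ccccc32)cc1`: > 50000 nM
- compound 2, `N#CC1=C(N)Oc2c(c3nc4ccccc4nc3c3ccccc23)C12C(=O)N(Cc1cnnn1-c1cccc(S(N)(=O)=O)c1)c1ccccc12`: 42500 nM
- compound 3, `N#CC1=C(N)Oc2c(N)cc3nc4ccccc4nc3c2C12C(=O)N(Cc1cnnn1-c1ccccc1Cl)c1ccccc12`: 34400 nM

All three share one core and differ only in the aryl group attached to the triazole nitrogen. In a functional assay on MCF7 cells (Homo sapiens) for antiproliferative activity, read by MTT assay, with a stated time of 48 h (a lower number here means a stronger inhibitor, a higher number a weaker inhibitor), compound 1 gives only a limit, > 50000 nM, not a number (the limit of > 50000 nM in this assay, at which 1 of the 3 values shown sits). In this assay compound 2 gives 42500 nM and compound 3 gives 34400 nM. Of the two numbers, that of compound 3 is the lower, but the gap to compound 2 is within the usual scatter, so the two are not distinguishable.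

Compound 4, `N#CC1=C(N)Oc2c(N)cc3nc4ccccc4nc3c2C12C(=O)N(Cc1cnnn1-c1ccc([N+](=O)[O-])cc1[N+](=O)[O-])c1ccccc12`, has not yet been measured. It differs from compound 3 in one place: 2,4-dinitrophenyl in place of 2-chlorophenyl on an aromatic nitrogen.

Among the compounds with values here, the one measured step at this same position, an at least 1.1-fold lower number from compound 1 to compound 2 (0.07 log units; that floor lies within the scatter), changed the number by an amount that lies within the scatter. On that basis, the step from compound 3 to compound 4 in this assay is expected to be small as well, a 1.1-fold lower number from compound 3 to compound 4 (0.03 log units; within the scatter), with no clear direction. Compound 4 is therefore estimated at 32000 nM, with a range from 12000 nM to 80000 nM.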

Compound 4, half-maximal inhibitory concentration: 20900 nM
Beside the measured number, compound 4's estimate is 1.5-fold (0.19 log units) above it; the range from low to high includes it.
By their numbers in this assay, from the lowest: compounds 4, 3 and 2 (each within the scatter of the next, the first and the last beyond it). At a limit, above all of these: compound 1.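

Replacing 2-chlorophenyl with 2,4-dinitrophenyl on the aromatic nitrogen gives a 1.6-fold lower number from compound 3 to compound 4 (0.22 log units; within the scatter) in this assay, so the two compounds cannot be told apart, even though the entering group has 12 heavy atoms against 7 and 4 hydrogen-bond acceptors against 0. Within the data shown here, the earlier step at this nitrogen started from compound 1, whose value is a limit and not a number, so this is the first step here with a measured number at both ends, and it shows that a much larger aryl group with two nitro groups keeps a measurable number in this cell assay. Nothing shown bears on what the nitro groups do in these cells, and the reading stops at this comparison.

The compounds shown leave open whether a group of a different kind on this nitrogen, such as an aryl ring carrying an amine or a carboxylic acid, or a plain longer alkyl chain in place of the aryl ring, would move the number beyond the scatter. They also leave open how a phenyl ring with a single nitro group would compare with compound 4.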